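Replacing 3,4-difluorophenyl in compound 1 with 4-bromophenyl

A few compounds are considered here, and "the series" means these few. Any claim that something is new, unique, unknown or untested is made for them only; others in the source may bear on it.

Within the data shown here, in a functional assay on A498 cells (Homo sapiens) for cytotoxicity (a lower number here means a stronger inhibitor of growth, a higher number a weaker inhibitor of growth), compound 1 `CSc1ccc(C2=C(c3ccc(F)c(F)c3)C(=O)N3CCCC3C2)cc1` gives 100 nM, the lowest of the three numbers measured so far and beyond the scatter of the other two. Compound 2 `CSc1ccc(C2=C(c3ccc(C)c(C)c3)C(=O)N3CCCC3C2)cc1` gives 300 nM, and compound 3 `CSc1ccc(C2=C(c3ccc(OCC4CO4)cc3)C(=O)N3CCCC3C2)cc1` gives 500 nM. All three keep the 4-(methylsulfanyl)phenyl group and differ in the substituted phenyl group on the double-bonded ring carbon.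

Compound 4 `CSc1ccc(C2=C(c3ccc(Br)cc3)C(=O)N3CCCC3C2)cc1` has not yet been measured. Its difference from compound 1 is 4-bromophenyl in place of 3,4-difluorophenyl on a double-bonded ring carbon: 4-bromophenyl in place of 3,4-difluorophenyl, on the double-bonded ring carbon next to the ring atom that bears the 4-(methylsulfanyl)phenyl group.

Among the measured compounds shown here, one measured step bears on this change: a 3.0-fold higher number from compound 1 to compound 2 (0.48 log units; beyond the scatter), a modest step with 3,4-dimethylphenyl in place of 3,4-difluorophenyl. For the measured compounds named here, compound 3 also shows a higher number than compound 1, but no measured step links the two. Going by the values given here, no measured compound carries 4-bromophenyl, so the size of this change remains uncertain. A modest move toward a higher number is the best reading. The expected step is a 2.0-fold higher number from compound 1 to compound 4 (0.30 log units; within the scatter), and it may not clear the scatter. For compound 4 the estimate is 200 nM, with an expected range from 70 nM to 500 nM.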

Compound 4, concentration for 50% growth inhibition: 7000 nM
For compound 4 the middle estimate is 35-fold (1.54 log units) below the measured one; measured number outside the range, above it.
By their numbers in this assay, from the lowest: compound 1; then compounds 2 and 3 (each within the scatter of the next); then compound 4.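

In this assay, the substituted phenyl group on the double-bonded ring carbon proves far less forgiving than the first three compounds suggested, since 4-bromophenyl in place of 3,4-difluorophenyl gives a much larger shift (a 70-fold higher number from compound 1 to compound 4 (1.85 log units; beyond the scatter)) than 3,4-dimethylphenyl does (a 3.0-fold higher number from compound 1 to compound 2 (0.48 log units; beyond the scatter)). Compound 4 also stands well apart from the other two analogues (a 23-fold higher number from compound 2 to compound 4 (1.37 log units; beyond the scatter); a 14-fold higher number from compound 3 to compound 4 (1.15 log units; beyond the scatter)), and compound 3, which likewise carries a single substituent on this phenyl group, goes against any reading that having only one substituent is enough to produce so high a number. Nothing available here accounts for this jump.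

Still open, from the compounds shown here alone, is whether 4-chlorophenyl or 3,4-dichlorophenyl would fall nearer compound 1 or compound 4, which would help separate the effect of the bromine from that of losing the second substituent. Going by these compounds, it is also open whether the same sensitivity would persist with 4-(methylsulfonyl)phenyl in place of the 4-(methylsulfanyl)phenyl group.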